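Methyl on the Amide Nitrogen: From Compound 2 to Compound 3

The source may report more compounds than this note shows. Statements on the series, on what has been measured and on what is new or still open speak of the compounds shown alone.

Among the measured compounds shown here, compound 2 `NC(=O)N(O)CC1=Cc2cc(Oc3ccc(F)cc3)ccc2OCC1` gives 98 nM in an assay on isolated protein (Cavia porcellus) for inhibition of Polyunsaturated fatty acid 5-lipoxygenase (Homo sapiens) (a lower number here means a stronger inhibitor, a higher number a weaker inhibitor), the higher of the two numbers measured so far; its nearest neighbour, compound 1 `NC(=O)N(O)CC1=Cc2cc(Oc3ccccc3)ccc2OCC1`, gives 91 nM, and the step of a 1.1-fold higher number from compound 1 to compound 2 (0.03 log units; within the scatter) lies within the scatter. Compound 3 `CNC(=O)N(O)CC1=Cc2cc(Oc3ccc(F)cc3)ccc2OCC1` differs from compound 2 by methyl in place of hydrogen on an amide-type nitrogen. For the measured compounds named here, no measured step touches this nitrogen: the only step known, a 1.1-fold higher number from compound 1 to compound 2 (0.03 log units; within the scatter), concerns a fluoro on an aromatic carbon and says nothing about a methyl on the amide-type nitrogen. Without a comparable step, the expectation for compound 3 can rest only on compound 2 and must allow a wider range than usual. The number for compound 3 is expected near 150 nM, with a range from 50 nM to 500 nM. The expected step of a 1.5-fold higher number from compound 2 to compound 3 (0.18 log units; within the scatter) is therefore modest, with no direction claimed beyond the scatter.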

Compound 3, half-maximal inhibitory concentration: 130 nM
For compound 3 the middle estimate is 1.2-fold (0.06 log units) above the measured one; measured number inside the range.
By their numbers in this assay, from the lowest: compounds 1, 2 and 3 (each within the scatter of the next).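

Methyl in place of hydrogen on the amide-type nitrogen gives a 1.3-fold higher number from compound 2 to compound 3 (0.12 log units; within the scatter) in this assay. The earlier step concerned only a fluoro on an aromatic carbon, whereas this one shows that the amide hydrogen of compound 2 can be replaced by methyl without a change that can be told from the scatter. Nothing available explains this result or says what the methyl does at this nitrogen.

The compounds shown leave open whether this tolerance extends beyond a single methyl, for example to an ethyl group, a longer chain or a phenyl ring on the same nitrogen. They also leave open whether a second methyl, giving dimethylamino in place of methylamino, would keep the number within the same range.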